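Carbamate in place of cyclopentylacetamide on the shared core

The source may hold more compounds than are shown below. What is called first, only, known or untested is meant among the compounds shown, and "the series" means these compounds.

Compound 2 `O=C(CC1CCCC1)Nc1c(C(O)(C(F)(F)F)C(F)(F)F)ccc2ccccc12` gives 81 nM in an assay on LtK cells with ATP-sensitive inward rectifier potassium channel 11 (Homo sapiens) as the target (a higher number here means that more compound is needed for the effect, a lower number that less compound is needed), the lower of the two numbers found so far; compound 1 `CCC(CC)C(=O)Nc1c(C(O)(C(F)(F)F)C(F)(F)F)ccc2ccccc12` gives 4340 nM. Going by the values given here, the one step measured, a 54-fold lower number from compound 1 to compound 2 (1.73 log units; beyond the scatter), shows that the group on the carbonyl carbon shifts this assay strongly. Compound 3 `CC(C)OC(=O)Nc1c(C(O)(C(F)(F)F)C(F)(F)F)ccc2ccccc12` differs from compound 2 by isopropoxy in place of cyclopentylmethyl on a carbonyl carbon. The change is again at the carbonyl carbon, so a step well beyond the scatter is expected, and because compound 1 with its branched group gave 4340 nM, a higher number seems more likely. Compound 3 is estimated at 1500 nM, within 200 nM to 10000 nM, a step of a 19-fold higher number from compound 2 to compound 3 (1.27 log units; beyond the scatter).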

Compound 3, half-maximal effective concentration: 1160 nM
For compound 3 the middle estimate is 1.3-fold (0.11 log units) above the measured one; low and high end bracket the measured number.
By their numbers in this assay, from the lowest: compound 2; then compound 3; then compound 1.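

In this assay a carbonyl carbon bearing isopropoxy, attached through oxygen, does not reach the level of cyclopentylmethyl, with a 14-fold higher number from compound 2 to compound 3 (1.16 log units; beyond the scatter). The same isopropoxy still improves on pentan-3-yl, with a 3.7-fold lower number from compound 1 to compound 3 (0.57 log units; beyond the scatter), so the three groups at this carbonyl carbon now give a graded order in which cyclopentylmethyl stays clearly lowest. No measurement shown here explains either step. As far as these compounds go, it remains open whether the low number of compound 2 depends on the ring itself, and how a cyclopentyloxy group, a longer straight chain or an amine on this carbonyl carbon would compare.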